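This account rests on a few compounds, and the source may have more. Where it says the series, first, only, none or still open, it means among the compounds named here.

Among the compounds with values here, compound 1 `C[C@@H](O)[C@H](NC(=O)CN(c1nc(Cl)nc2[nH]cnc12)C1CC1)C(=O)O` and compound 2 `NCCCC[C@H](NC(=O)CN(c1nc(Cl)nc2[nH]cnc12)C1CC1)C(=O)OCc1ccccc1` are the two measured members of this set. In a functional assay on the whole organism (Tail, strain ICR) with Mus musculus as the target, in the tail flick test, with a stated time of 90 min, at a dose of 25 umol/kg by the oral route (a higher number here means a stronger effect of the compound at the dose given, a lower number a weaker effect), compound 1 gives 35.9%. In this assay compound 2 gives 35.3%, the lower of the two numbers, although the gap to compound 1 lies within the usual scatter, so the two read as alike. Compound 3 `O=C(CN(c1nc(Cl)nc2[nH]cnc12)C1CC1)N[C@@H](CCC(=O)OCc1ccccc1)C(=O)OCc1ccccc1` differs from compound 2 by benzyloxycarbonyl in place of 2-aminoethyl on a saturated chain carbon, three bonds along the chain from an amide-type nitrogen and a carbonyl carbon. Nothing measured shows how this change acts, so the expected step of a number 2.3 percentage points lower from compound 2 to compound 3 (within the scatter) is none beyond the scatter, with a wide margin. Compound 3 is therefore estimated at 33%, between 15% and 55%.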

Compound 3, a percentage reported as activity, at one dose (the size of the read-out at that dose, not a potency): 50%
Compound 3: middle estimate off by 17 percentage points, on the low side; low and high end bracket the measured number.
By their numbers in this assay, from the lowest: compounds 2 and 1 (each within the scatter of the next); then compound 3.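

The saturated chain carbon three bonds along the chain from an amide-type nitrogen and a carbonyl carbon proves open to change in this assay: benzyloxycarbonyl in place of 2-aminoethyl gives a number 14.7 percentage points higher from compound 2 to compound 3 (beyond the scatter), a modest step. In this pair, losing the 2-aminoethyl group costs no effect at the dose given. Nothing at hand gives a reason for the step.

A single pair cannot separate the share of the aromatic ring from that of the ester carbonyl. Going by these compounds, how a carboxylic acid or a methyl ester would read in place of benzyloxycarbonyl on this carbon remains open.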